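A few compounds are considered here, and "the series" means these few. Any claim that something is new, unique, unknown or untested is made for them only; others in the source may bear on it.

Measured so far in a functional assay on CCRF-CEM cells for antagonist activity at C-X-C chemokine receptor type 4 (Homo sapiens), read by calcium flux, with stated times of 25 min and 90 s; on this read-out lower numbers stand for stronger inhibition and higher numbers for weaker inhibition:
compound 1 `N[C@H]1CC[C@H](CN(C[C@H]2Cc3ccccc3CN2)[C@H]2CCCc3cccnc32)CC1`, 280 nM
compound 2 `C/C(=C/CN(C[C@H]1Cc2ccccc2CN1)[C@H]1CCCc2cccnc21)CN`, 8.6 nM
compound 3 `NCC1=C(CN(C[C@H]2Cc3ccccc3CN2)[C@H]2CCCc3cccnc32)CCCC1`, 230 nM

For the measured compounds named here, compound 3 sits second highest of the three, within the scatter of compound 1 and far from compound 2, which gave the only low number. The step to compound 4 `NC(=O)NC/C=C\CN(C[C@H]1Cc2ccccc2CN1)[C@H]1CCCc2cccnc21` is a group of 7 heavy atoms (4 carbon, 2 nitrogen, 1 oxygen; no ring) in place of a group of 8 heavy atoms (7 carbon, 1 nitrogen; one six-membered non-aromatic ring of carbon only), on a saturated chain carbon bound to an amine nitrogen. The bearing steps are those in which a ring group gives way to an open chain: a 33-fold lower number from compound 1 to compound 2 (1.51 log units; beyond the scatter) and, in the reverse sense, a 27-fold higher number from compound 2 to compound 3 (1.43 log units; beyond the scatter). Both were large; a 1.2-fold lower number from compound 1 to compound 3 (0.09 log units; within the scatter) was not. Compound 4 likewise carries no ring, so a drop is expected, yet the entering group differs from that of compound 2 in its nitrogen and oxygen count, so a smaller step than those two is assumed. Compound 4 is thus expected at 100 nM, range 20 nM to 600 nM, a step of a 2.3-fold lower number from compound 3 to compound 4 (0.36 log units; beyond the scatter).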

Compound 4, half-maximal inhibitory concentration: 210 nM
Beside the measured number, compound 4's estimate is 2.1-fold (0.32 log units) below it; the measured number falls inside the stated range.
By their numbers in this assay, from the lowest: compound 2; then compounds 4, 3 and 1 (each within the scatter of the next).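

Losing the ring at this position does not by itself give a low number: compound 4 has no ring, yet there is a 24-fold higher number from compound 2 to compound 4 (1.39 log units; beyond the scatter). Compound 4 also stays level with both ring-bearing compounds, with a 1.1-fold lower number from compound 3 to compound 4 (0.04 log units; within the scatter) and a 1.3-fold lower number from compound 1 to compound 4 (0.12 log units; within the scatter), so the large steps seen earlier depend on the particular open chain and not only on the absence of a ring. Nothing available explains this difference between the two open chains.

As far as these compounds go, it remains open whether the methyl group, double-bond geometry or terminal amine of compound 2 separates it from compound 4. From the compounds shown here alone, how a carboxylic acid or a longer chain would read at this place also remains open.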